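Working notes: the step from compound 2 to compound 4

The compounds below may be only part of what the source reports. "The series", "measured", "known", "first", "only" and "open" are said of these compounds alone.

Measured compounds:
- compound 1 `NC(=S)N/N=C/c1cccc(OCc2ccc3no[n+]([O-])c3c2)c1`: "nd(insoluble)" (no result reported)
- compound 2 `N=C(N)N/N=C\c1ccccc1OCc1ccc2no[n+]([O-])c2c1`: 58 uM
- compound 3 `[O-][n+]1onc2ccc(COc3ccccc3/C=N\NC(=S)Nc3ccccc3)cc21`: > 200 uM

For the measured compounds named here, in an ADME assay on cells (Erythrocyte, Homo sapiens), read by spectrophotometry and hemolysis, with a stated time of 24 h (on this read-out higher numbers stand for weaker inhibition and lower numbers for stronger inhibition), compound 2 gives 58 uM, the only actual number. Compound 3 reads > 200 uM, which is a limit of the assay. Compound 1 gave no number: "nd(insoluble)" (no result reported).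

Compound 4 `C/C(=N/NC(=N)N)c1ccccc1OCc1ccc2no[n+]([O-])c2c1` is next. Its difference from compound 2 is a group of 7 heavy atoms (3 carbon, 4 nitrogen; no ring) in place of a group of 6 heavy atoms (2 carbon, 4 nitrogen; no ring), on an aromatic carbon, ortho to a large group. Going by the values given here, the one measured step, an at least 3.4-fold higher number from compound 2 to compound 3 (0.53 log units; beyond the scatter), lies beyond the scatter, but it ends at the limit of > 200 uM in this assay, at which 1 of the 3 values shown sits, so its true size is open. That step is on an amine nitrogen and exchanges far more of the molecule than the change in compound 4, so it bears only weakly here. No step beyond the scatter is therefore expected in this assay, in either direction. The estimated 1.0-fold higher number from compound 2 to compound 4 (0.01 log units; within the scatter) is expected to stay within the scatter. The estimated value for compound 4 is 60 uM, with an expected range of 25 uM to 150 uM.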

Compound 4, concentration for 50% inhibition: > 200 uM
Compound 4: only a limit was reported; the forecaster's own chance of this, stated with the estimate: 10%; middle value at least 3.3-fold (0.52 log units) away from the limit.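

In this assay, the change on the aromatic carbon, ortho to a large group, does move the read-out: an at least 3.4-fold higher number from compound 2 to compound 4 (0.53 log units; beyond the scatter). Compound 4 reads > 200 uM, which is a limit of the assay and not a number. For the compounds shown here, the only earlier step that could be read, an at least 3.4-fold higher number from compound 2 to compound 3 (0.53 log units; beyond the scatter), was on an amine nitrogen and brought in a group of 9 heavy atoms, whereas here a group of 7 heavy atoms replacing a group of 6 heavy atoms reaches the same limit: the limit of > 200 uM in this assay, at which 2 of the 4 values shown sit.

The true size of the new step stays open, and the compounds shown give no reason for it. As far as these compounds go, whether a longer chain or an amine in the group at this place would give a number in this read-out also stays open.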